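Free Oxime Versus (4-Chlorophenyl)carbonyl Ester in Compound 1

The source may report more compounds than this note shows. Statements on the series, on what has been measured and on what is new or still open speak of the compounds shown alone.

Compound 1 `COc1cc(C2CC(=NOC(=O)c3ccc(Cl)cc3)CC(c3ccc(O)c(OC)c3)N2C)ccc1O` holds the higher of the two numbers gathered so far in a functional assay on microsomes from liver (Rattus norvegicus, strain Wistar) for inhibition, read by spectrophotometry, with a stated time of 60 min (a lower number here means a stronger inhibitor, a higher number a weaker inhibitor), where compound 1 gives 121000 nM. Within the data shown here, its only neighbour is compound 2 `COc1cc(C2CC(=NOC(=O)c3ccc([N+](=O)[O-])cc3)CC(c3ccc(O)c(OC)c3)N2C)ccc1O`, which in this assay gives 82000 nM; the step of a 1.5-fold lower number from compound 1 to compound 2 (0.17 log units; within the scatter) lies within the scatter, so the two cannot be put in order.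

Compound 3 `COc1cc(C2CC(=NO)CC(c3ccc(O)c(OC)c3)N2C)ccc1O` differs from compound 1 in one place: hydrogen in place of (4-chlorophenyl)carbonyl on an oxygen. Among the measured compounds shown here, the single measured step exchanges one substituent on the aromatic ring for another while the ester stays in place, so it bears only loosely on a change that removes the whole (4-chlorophenyl)carbonyl group, and that step was itself within the scatter. For the measured compounds named here, no measured pair speaks directly to the loss of the ester. With nothing beyond the scatter among the measured compounds, the expectation for compound 3 is a step of a 1.2-fold lower number from compound 1 to compound 3 (0.08 log units; within the scatter), not clearly beyond the scatter in either direction. Compound 3 is therefore estimated at 100000 nM, with a range from 30000 nM to 400000 nM.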

Compound 3, half-maximal inhibitory concentration: 167000 nM
Compound 3: middle estimate off by 1.7-fold (0.22 log units), on the low side; the range from low to high includes it.
By their numbers in this assay, from the lowest: compounds 2, 1 and 3 (each within the scatter of the next, the first and the last beyond it).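

Removing the (4-chlorophenyl)carbonyl from the oxygen on the double-bonded nitrogen gives a 1.4-fold higher number from compound 1 to compound 3 (0.14 log units; within the scatter) in this assay and so leaves compound 1 and compound 3 unordered, which shows that this whole group can leave without a clear change in the number. The matching loss of (4-nitrophenyl)carbonyl gives a 2.0-fold higher number from compound 2 to compound 3 (0.31 log units; beyond the scatter) and is a modest step, the only one among these compounds to clear the scatter, with compound 2 the stronger inhibitor of that pair. The free oxime therefore brings no measured gain over either ester at this position, but a general claim that the esters are stronger than the free oxime fails on compound 1, which goes against it.

The compounds shown leave open whether a small acetyl group or a methyl ether on this same oxygen would behave like the two aromatic esters or like the free oxime, and whether a benzoyl group with no ring substituent would fall with them. Nothing available explains why the numbers fall as they do.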